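From hydroxy to dimethylamino on the side chain

This account rests on a few compounds, and the source may have more. Where it says the series, first, only, none or still open, it means among the compounds named here.

Compound 1 `COC1=CC(=O)c2ncnc(NCCCN(C)C)c2C1=O` gives 1730 nM
Compound 2 `COC1=CC(=O)c2ncnc(NCCO)c2C1=O` gives 7130 nM

Going by the values given here, in a functional assay on L1210 cells (Mus musculus) for inhibition (on this read-out lower numbers stand for stronger inhibition and higher numbers for weaker inhibition), compound 2 gives 7130 nM and so holds the higher of the two numbers so far. The change to compound 3 `COC1=CC(=O)c2ncnc(NCCN(C)C)c2C1=O` is a single one (dimethylamino in place of hydroxy on a saturated chain carbon, two bonds along the chain from a nitrogen on an aromatic ring): dimethylamino in place of hydroxy on a saturated chain carbon, two bonds along the chain from a nitrogen on an aromatic ring. Among the compounds with values here, one measured step bears on it (a 4.1-fold higher number from compound 1 to compound 2 (0.62 log units; beyond the scatter)), and that step is modest. Read in reverse, it points to a lower number for a chain ending in dimethylamino, although compound 1 carries (dimethylamino)methyl where compound 3 carries dimethylamino. A lower number of similar size is therefore expected (a 3.2-fold lower number from compound 2 to compound 3 (0.51 log units; beyond the scatter)). In this assay compound 3 is expected at 2200 nM with 900 nM to 5500 nM as the estimated range.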

Compound 3, half-maximal inhibitory concentration: 1140 nM
Estimate against measurement, compound 3: 1.9-fold (0.29 log units) above; the range from low to high includes it.
By their numbers in this assay, from the lowest: compounds 3 and 1 (each within the scatter of the next); then compound 2.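

In this assay, the exchange of hydroxy for dimethylamino on a saturated chain carbon, two bonds along the chain from a nitrogen on an aromatic ring, now stands as a direct step, a 6.3-fold lower number from compound 2 to compound 3 (0.80 log units; beyond the scatter), whereas the earlier step also altered the chain. The two chains ending in dimethylamino cannot be told apart, with a 1.5-fold lower number from compound 1 to compound 3 (0.18 log units; within the scatter), and each stands clear of the hydroxy chain of compound 2. No measurement at hand accounts for the step from hydroxy to dimethylamino.

From the compounds shown here alone, it remains open whether the gain follows from the amine itself or from the loss of hydroxy, which a primary amine, a methoxy group or a carboxylic acid on the same chain carbon could separate. Going by these compounds, how a longer chain ending in dimethylamino, or a morpholine in its place, would read in this assay also remains open.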